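A few compounds are considered here, and "the series" means these few. Any claim that something is new, unique, unknown or untested is made for them only; others in the source may bear on it.

In a functional assay on A2780 cells (Homo sapiens) for antiproliferative activity, read by CellTiter-Glo, with a stated time of 4 days (on this read-out lower numbers stand for stronger inhibition and higher numbers for weaker inhibition), compound 1 `O=C(CCc1cccnc1)Nc1ccc(CN2C(=O)c3ccccc3C2=O)cc1` gives > 10000 nM, which is a limit of the assay and not a number. Going by the values given here, compound 2 `CCC(=O)NCc1ccc(NC(=O)[C@H]2C[C@@H]2c2cccnc2)cc1` gives 405 nM, the only actual number so far. Compound 3 `CCC(=O)NC(C)(C)c1ccc(NC(=O)[C@H]2C[C@@H]2c2cccnc2)cc1` differs from compound 2 in one place, on an aromatic carbon para to a large group: a group of 8 heavy atoms (6 carbon, 1 nitrogen, 1 oxygen; no ring) in place of a group of 6 heavy atoms (4 carbon, 1 nitrogen, 1 oxygen; no ring), on an aromatic carbon. Among the compounds with values here, no measured step bears on this change, so no shift beyond the scatter is expected in this assay, and no direction can be firmly called. The estimated step is a 1.4-fold lower number from compound 2 to compound 3 (0.13 log units; within the scatter). For compound 3 the expected value is 300 nM, with an estimated range of 70 nM to 1300 nM.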

Compound 3, half-maximal inhibitory concentration: 832 nM
Compound 3: the middle estimate sits 2.8-fold (0.44 log units) below what was measured, within the range that was stated.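

In this assay, going by these compounds alone, this is the first measured change at this aromatic carbon, and it gives a 2.1-fold higher number from compound 2 to compound 3 (0.31 log units; beyond the scatter) on going to the group of 8 heavy atoms. The position therefore responds to this change, though only modestly, and compound 3 keeps a measured number rather than a limit. The entering group has the same counts of hydrogen-bond donors and acceptors as (propanoylamino)methyl, so those counts do not distinguish the pair. Going by these compounds, how an amine, a carboxylic acid or a longer chain would fare at this carbon remains open. Nothing shown here explains the shift.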